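Hydroxy for Fluoro on the Aryl Ring of Compound 2

A few compounds are considered here, and "the series" means these few. Any claim that something is new, unique, unknown or untested is made for them only; others in the source may bear on it.

Measured compounds:
- compound 1 `COc1ccc(-c2nc(NN)n(C)c(=O)c2C#N)cc1` gives 32 ug/mL
- compound 2 `CCOC(=O)c1cnn(-c2nc(-c3ccccc3F)c(C#N)c(=O)n2C)c1N` gives 86 ug/mL

Both numbers come from a functional assay, with a stated time of 10 min; a lower number here means a stronger inhibitor, a higher number a weaker inhibitor. Of the two, compound 2 has the higher number, and its gap to compound 1 lies beyond the usual scatter, so compound 2 is the weaker inhibitor of the pair. The two share the nitrile-bearing core but differ in several places at once, so nothing can be said about which change matters.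

Compound 3 `CCOC(=O)c1cnn(-c2nc(-c3ccccc3O)c(C#N)c(=O)n2C)c1N` is the unmeasured partner of compound 2. The difference is a single swap, (hydroxy in place of fluoro on an aromatic carbon). Hydroxy in place of fluoro on an aromatic carbon brings one hydrogen-bond donor and one acceptor where the fluorine offered none.

Going by the values given here, with no measured pair showing this swap, the expected step is small: a 1.1-fold lower number from compound 2 to compound 3 (0.03 log units; within the scatter) is estimated to stay within the scatter, with no clear direction. Compound 3 is therefore expected to give about 80 ug/mL in this assay, in a range from 30 ug/mL to 200 ug/mL.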

Compound 3, half-maximal inhibitory concentration: 58 ug/mL
The estimate for compound 3 lay 1.4-fold (0.14 log units) above the measured number; the range from low to high includes it.
By their numbers in this assay, from the lowest: compounds 1, 3 and 2 (each within the scatter of the next, the first and the last beyond it).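

Going by these compounds alone, compound 2 and compound 3 form the first pair here that differs in only one place, so this swap can be read on its own, unlike the gap between compound 1 and compound 2. In this assay, going from 2-fluorophenyl to 2-hydroxyphenyl gives a 1.5-fold lower number from compound 2 to compound 3 (0.17 log units; within the scatter) and so does not separate the two compounds. On this aromatic carbon, ortho to a large group, a hydroxy with its hydrogen-bond donor and acceptor therefore reads the same as a fluoro with neither, and no measurement shown here explains that result.

One swap at one position cannot show whether other groups would also read the same here, and an amine or a plain hydrogen on this carbon would test how far that holds. The compounds shown also leave open whether the same swap would read alike with a different group in place of the amino-ester pyrazole part, or whether a carboxylic acid in place of the ethyl ester would move the number at all.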